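Swapping Trifluoromethoxy for Trifluoromethyl on Two Related Cores

The source may hold more compounds than are shown below. What is called first, only, known or untested is meant among the compounds shown, and "the series" means these compounds.

Measured so far in an assay on isolated protein for inhibition of DNA topoisomerase 1 (Homo sapiens), with a stated time of 30 min, tested at 100 uM; on this read-out lower numbers stand for a weaker effect and higher numbers for a stronger effect at the one concentration tested:
compound 1 `Cc1ccc2nc(-c3cccc(C(F)(F)F)c3)[nH]c(=O)c2c1` gives 45.8%
compound 2 `Cc1ccc2nc(-c3cccc(OC(F)(F)F)c3)[nH]c(=O)c2c1` gives 98.6%
compound 3 `Cc1ccc2c(=O)[nH]c(-c3cccc(OC(F)(F)F)c3)nc2c1` gives 77.2%

Compound 2 and compound 3 are built from the same atoms joined differently; the difference between the two cores is not broken down here. On the core of compound 2, the change from compound 2 to compound 1 is trifluoromethyl in place of trifluoromethoxy on an aromatic carbon and it produced a step of a number 52.8 percentage points lower from compound 2 to compound 1 (beyond the scatter) in this assay, a drop that lies well beyond the scatter of repeated measurements.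

Compound 4 `Cc1ccc2c(=O)[nH]c(-c3cccc(C(F)(F)F)c3)nc2c1` has not yet been tested. It differs from compound 3 by trifluoromethyl in place of trifluoromethoxy on an aromatic carbon, the same change already seen between compound 2 and compound 1, made here on the core of compound 3. Among the compounds shown this change occurs twice in all, and only one instance has been measured, so any expectation rests on that single step.

If the change acts alike on both cores, compound 4 is expected to fall by roughly a number 49.2 percentage points lower from compound 3 to compound 4 (beyond the scatter) in this assay relative to compound 3, because compound 3 starts from 77.2% and the earlier change gave a number 52.8 percentage points lower from compound 2 to compound 1 (beyond the scatter). With one measured instance and a different core, the range is kept wide. For compound 4 the estimated inhibition is 28%, expected to lie between 5% and 55%.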

Compound 4, a percentage reported as inhibition, at one concentration (the size of the read-out at that concentration, not a potency): 100%
For compound 4 the middle estimate is 72 percentage points below the measured one; measured number above the stated range.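

In this assay, placing trifluoromethyl where trifluoromethoxy stood on the core of compound 3 gives a number 22.8 percentage points higher from compound 3 to compound 4 (beyond the scatter) and so runs opposite to the earlier step on the core of compound 2. What these four compounds show is that, in this series, the outcome of this one change depends on the core that carries it, so the step measured on one core could not be carried over to the other in either size or direction. They do not show why the two cores part, and with only two pairs and a single concentration, which reports the size of the read-out rather than a potency, they set no rule for any further core, yet the disagreement itself is clear: the same change on two cores in this assay, a number 52.8 percentage points lower (beyond the scatter) from compound 2 to compound 1 and a number 22.8 percentage points higher (beyond the scatter) from compound 3 to compound 4, 75.6 percentage points apart, beyond the scatter of two such steps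

The compounds shown leave open whether this dependence on the core is special to the pair of trifluoromethyl and trifluoromethoxy or also appears with other groups on the same aromatic carbon, such as a methoxy, a nitrile, a chlorine or a carboxylic acid. They also leave open how the two cores would compare at other concentrations, as the read-out here tells only of a stronger or weaker effect at the one concentration tested.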